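This account rests on a few compounds, and the source may have more. Where it says the series, first, only, none or still open, it means among the compounds named here.

Compound 1 `Fc1ccc2c(c1CNc1ncc(Oc3ccccc3)c3nncn13)CCO2` gives the highest reading of the three compounds measured in a physicochemical assay for lipophilicity, using the shake flask method, in phosphate buffer, measured as octanol-water partition, with a stated time of 30 min, at pH 7.4 (on this read-out higher numbers stand for higher lipophilicity and lower numbers for lower lipophilicity), at 3.5. Compound 2 `Cn1nccc1-c1cnc(NCc2c(F)ccc3c2CCO3)c2cn[nH]c(=O)c12` gives 2.6 in this assay, and compound 3 `Cc1ncccc1-c1cnc(NCc2c(F)ccc3c2CCO3)c2n[nH]c(=O)n12` gives 2.5; both gaps to compound 1 are beyond the scatter, with compound 2 the nearest and compound 3 the furthest from it. Compound 4 `C[C@H]1CC(=O)N(c2cnc(NCc3c(F)ccc4c3CCO4)n3cnnc23)C1` has not yet been measured in this assay. It differs from compound 1 in one place: 4-methyl-2-oxopyrrolidin-1-yl in place of phenoxy on an aromatic carbon. Going by the values given here, no measured pair shows this change. The step from compound 1 to compound 4 is expected to be a clear fall, estimated as a number 1.50 log units lower from compound 1 to compound 4 (beyond the scatter). Compound 4 is therefore expected to give about 2, within a range from 1.4 to 2.6.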

Compound 4, distribution coefficient: 1.8
For compound 4 the middle estimate is 0.20 log units above the measured one; the range from low to high includes it.
By their numbers in this assay, from the lowest: compound 4; then compounds 3 and 2 (each within the scatter of the next); then compound 1.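

In this assay, going by these compounds alone, 4-methyl-2-oxopyrrolidin-1-yl in place of phenoxy on this aromatic carbon gives a number 1.70 log units lower from compound 1 to compound 4 (beyond the scatter), the first single-place change that can be read at this position. Both groups have 7 heavy atoms and 1 hydrogen-bond acceptor, so this large step comes with no difference in those counts. Nothing measured here accounts for the step. The compounds shown leave open whether the step follows from the ring itself, its methyl group or its defined stereocentre. They also leave open how a morpholine or a simple amine would read on this carbon.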